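The source may hold more compounds than are shown below. What is called first, only, known or untested is meant among the compounds shown, and "the series" means these compounds.

Measured so far in a functional assay on the whole organism (stomach) for inhibition, with Canis familiaris (Canis lupus familiaris) as the target, at a dose of 20 mg/kg by the oral route; on this read-out higher numbers stand for a stronger effect at the one dose given and lower numbers for a weaker effect:
compound 1 `Cc1cc(C)nc(N(CCNC(C)C)C(=O)N(C)C)c1` — 33%
compound 2 `Cc1cc(Cl)nc(N(CCN(C(C)C)C(C)C)C(=O)N(C)C)c1` — 71%
compound 3 `Cc1cc(N(CCN(C(C)C)C(C)C)C(=O)N(C)C)nc(C)c1Cl` — 95%

In this assay compound 1 stands lowest of the three numbers; the nearest is compound 2, higher by a margin beyond the scatter, and the furthest is compound 3, higher still, also beyond the scatter. Compound 4 `Cc1cc(C)nc(N(CCCN(C(C)C)C(C)C)C(=O)N(C)C)c1` has not yet been measured. It differs from compound 1 in one place: (diisopropylamino)methyl in place of isopropylamino on a saturated chain carbon, two bonds along the chain from an amide-type nitrogen. Among the compounds with values here, no pair of measured compounds differs in only this way, so the size of this step has not been observed. Compounds 2 and 3 differ from compound 1 in more than one place, so their higher numbers give only weak guidance. A step upward in this assay is expected, of moderate size, a number 22 percentage points higher from compound 1 to compound 4 (beyond the scatter). For compound 4 the expected value is 55%, within 35% to 75%.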

Compound 4, a percentage reported as inhibition, in the whole organism at one dose (the size of the read-out at that dose, not a potency): 0%
Beside the measured number, compound 4's estimate is 55 percentage points above it, and the stated range ends above it.
By their numbers in this assay, from the lowest: compound 4; then compound 1; then compound 2; then compound 3.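

In this assay, within the data shown here, the exchange of isopropylamino for (diisopropylamino)methyl on a saturated chain carbon, two bonds along the chain from an amide-type nitrogen, gives a number 33 percentage points lower from compound 1 to compound 4 (beyond the scatter) and is the first step read at this position. The change removes the one hydrogen-bond donor of the group and takes it from 4 to 8 heavy atoms, and compound 4 stands at 0% in this read-out. Nothing measured here accounts for the loss.

The compounds shown leave open whether the longer chain or the second isopropyl carries the step. (Isopropylamino)methyl at this place would separate the two.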